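Hydroxy on the aniline of compound 1

The compounds below may be only part of what the source reports. "The series", "measured", "known", "first", "only" and "open" are said of these compounds alone.

Compound 1 `COc1cc2sc(Nc3ccccc3)c(C#N)c2cc1OC` gives 77% in a functional assay on HUVEC cells (Homo sapiens), read by fluorescence and microscopy, with a stated time of 6 h, tested at 10 uM (a lower number here means a stronger effect, a higher number a weaker effect of the compound at the concentration tested), the highest of the two numbers to hand. For the measured compounds named here, compound 2 `N#Cc1c(Nc2ccc([N+](=O)[O-])cc2)sc2ccccc12` gives 8% in this assay, a number lower than that of compound 1 by more than the scatter; no single-point step links the two. Compound 3 `COc1cc2sc(Nc3ccc(O)cc3)c(C#N)c2cc1OC` differs from compound 1 by hydroxy in place of hydrogen on an aromatic carbon. Without any measured step of this kind, a moderate move toward a lower number in this assay is expected, possibly not beyond the scatter. For compound 3 the expected value is 60%, with a range of 25% to 95%. The step of a number 17 percentage points lower from compound 1 to compound 3 (beyond the scatter) is expected accordingly.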

Compound 3, a percentage reported as activity, at one concentration (the size of the read-out at that concentration, not a potency): 0%
For compound 3 the middle estimate is 60 percentage points above the measured one; the whole stated range lies above it.
By their numbers in this assay, from the lowest: compounds 3 and 2 (each within the scatter of the next); then compound 1.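

For the compounds shown here, the change from phenyl to 4-hydroxyphenyl on compound 1 gives the first single-point step: in this assay the step is a number 77 percentage points lower from compound 1 to compound 3 (beyond the scatter) and it is large. This position, para to a large group, therefore responds strongly in this assay to the entry of 1 heavy atom. No evidence at hand bears on the reason for this step.

From the compounds shown here alone, it remains open whether methoxy or an amine at the same place would give a step of similar size. Going by these compounds, the effect of hydroxy at other carbons of this ring also remains open.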